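Ester to Acid on a Benzofuran Sulfonamide Pair

The source may report more compounds than this note shows. Statements on the series, on what has been measured and on what is new or still open speak of the compounds shown alone.

Measured compounds:
Compound 1 `CCOC(=O)c1oc2ccc(NS(=O)(=O)c3ccc(C(F)(F)F)cc3)cc2c1C` gives 5030 nM in a functional assay on HCT-116 cells (Homo sapiens) for inhibition, read by MTT assay, with a stated time of 72 h; a higher number here means a weaker inhibitor, a lower number a stronger inhibitor.
Compound 2 `CCOC(=O)c1oc2ccc(N(Cc3ccccc3)S(=O)(=O)c3ccc(C(F)(F)F)cc3)cc2c1C` gives 26700 nM in this assay.

Among the measured compounds shown here, compound 2 stands at the higher of the two numbers measured in this assay; its nearest neighbour is compound 1, and the only measured step, a 5.3-fold higher number from compound 1 to compound 2 (0.72 log units; beyond the scatter), places a benzyl group in place of hydrogen on the sulfonamide nitrogen.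

Compound 3 `Cc1c(C(=O)O)oc2ccc(N(Cc3ccccc3)S(=O)(=O)c3ccc(C(F)(F)F)cc3)cc12` is the unmeasured member. It differs from compound 2 by hydrogen in place of ethyl on an oxygen next to a carbonyl group: the ethyl group leaves and hydrogen enters on the oxygen next to the carbonyl group, so the ethoxycarbonyl becomes a carboxy group. For the measured compounds named here, no measured step bears on this change; the one step that exists concerns the sulfonamide nitrogen and offers no guidance for the ester oxygen. The expectation therefore rests on compound 2 alone, with a wide range.

Compound 3 is expected to give about 40000 nM in this assay, between 10000 nM and 160000 nM. The expected step of a 1.5-fold higher number from compound 2 to compound 3 (0.18 log units; within the scatter) is judged as no change beyond the scatter, though the uncertainty is large.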

Compound 3, half-maximal inhibitory concentration: 4130 nM
Compound 3: the middle estimate sits 9.7-fold (0.99 log units) above what was measured; measured number below the stated range.
By their numbers in this assay, from the lowest: compounds 3 and 1 (each within the scatter of the next); then compound 2.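

In this assay, the oxygen next to a carbonyl group proves to be a place where a single change registers: ethoxycarbonyl becoming carboxy on the benzyl-bearing sulfonamide gives a 6.5-fold lower number from compound 2 to compound 3 (0.81 log units; beyond the scatter). Among the compounds shown here, the only earlier step concerned the sulfonamide nitrogen, so this is the first reading at this position, and it shows that removing the ethyl group, with its 2 heavy atoms, goes with a lower number, although this rests on a single pair. Nothing among the data shown accounts for the size or direction of this step.

It remains open whether the same exchange would give a step of similar size with hydrogen on the sulfonamide nitrogen, as in compound 1, for the ester-to-acid pair shown here carries the benzyl group on both sides. Also open, as far as these compounds go, is how a methyl ester, a primary amide or a tetrazole in place of the carboxy group would read in this assay, and so whether the step is particular to the carboxylic acid.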